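The source may report more compounds than this note shows. Statements on the series, on what has been measured and on what is new or still open speak of the compounds shown alone.

Measured so far:
- compound 1, `Cc1ccc(OCc2ccccc2)c(C/C=C/c2ccccc2/C=C/C(=O)NS(=O)(=O)c2cccs2)c1`: 2300 nM
- compound 2, `O=C(/C=C/c1ccccc1/C=C/Cc1ccccc1)NS(=O)(=O)c1cccs1`: 8500 nM

Both compounds were tested in an assay on isolated protein for binding affinity to prostaglandin E2 receptor EP1 subtype (Homo sapiens); a lower number here means a stronger inhibitor, a higher number a weaker inhibitor. Compound 2 stands at the higher of the two numbers, and compound 1 sits a good distance lower, a gap that lies beyond the usual scatter of this kind of measurement. The two structures differ in more than one place, so their values are simply reported side by side without a single cause attached.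

Compound 3, `COc1ccc(C/C=C/c2ccccc2/C=C/C(=O)NS(=O)(=O)c2cccs2)cc1`, is the next one to be measured in this assay . It is built from compound 2 by one change: methoxy in place of hydrogen on an aromatic carbon. Among the measured compounds shown here, there is no comparable single-point step among the measured pairs to lean on, so the expectation rests on the structural change alone. A small step downward from compound 2 to compound 3 is expected, as a 1.7-fold lower number from compound 2 to compound 3 (0.23 log units; within the scatter), though a result within the scatter would not be surprising. Compound 3 is therefore estimated to give 5000 nM, with a plausible range from 1500 nM to 15000 nM.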

Compound 3, inhibition constant: 2600 nM
For compound 3 the middle estimate is 1.9-fold (0.28 log units) above the measured one, and the stated range covers the measured number.
By their numbers in this assay, from the lowest: compounds 1 and 3 (each within the scatter of the next); then compound 2.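

In this assay, putting methoxy in place of hydrogen on the six-membered aromatic ring, para to a large group, gives a 3.3-fold lower number from compound 2 to compound 3 (0.51 log units; beyond the scatter). Among the compounds shown here, this is the first step that changes one place only, and it shows that this aromatic carbon is not indifferent to substitution: a group of just two heavy atoms moves the number beyond the scatter. No measurement at hand explains the change, so the step stands as an observation without a known cause.

On these data alone, whether this step is specific to methoxy remains open, since a single group cannot show how fluorine, a hydroxyl group or the longer ethoxy group would behave at this carbon. Also open, as far as these compounds go, is whether methoxy on another carbon of the same ring would give a step of similar size.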